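The compounds below may be only part of what the source reports. "The series", "measured", "known", "first", "only" and "open" are said of these compounds alone.

Measured so far in a functional assay, with a stated time of 30 min; on this read-out higher numbers stand for weaker inhibition and lower numbers for stronger inhibition
compound 1 `COc1cc(O)c(C(C)=O)cc1Br` gives 41800000 nM
compound 2 `CCOc1cc(OC)c(Br)cc1C(C)=O` gives 46800000 nM
compound 3 `CCCCOc1cc(OC)c(Br)cc1C(C)=O` is not yet measured

Compound 2 at 46800000 nM stands within the scatter of compound 1, so these two numbers give no order. The next change is ethyl in place of hydrogen on a saturated chain carbon, two bonds along the chain from an oxygen on an aromatic ring and reads as ethoxy to butoxy: ethyl in place of hydrogen on a saturated chain carbon, two bonds along the chain from an oxygen on an aromatic ring. Among the compounds with values here, only one measured step bears on it, a 1.1-fold higher number from compound 1 to compound 2 (0.05 log units; within the scatter) for ethyl in place of hydrogen on an oxygen on an aromatic ring. That step sits at a different place, and no lengthening of this chain has been measured, so the basis is thin. Within the data shown here, with a 1.1-fold higher number from compound 1 to compound 2 (0.05 log units; within the scatter) as the only guide, the expected result in this assay is a 1.0-fold lower number from compound 2 to compound 3 (0.02 log units; within the scatter) and no shift beyond the scatter. Compound 3 is estimated at 45000000 nM with an expected range from 20000000 nM to 100000000 nM on this read-out.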

Compound 3, half-maximal inhibitory concentration: 42300000 nM
Compound 3: middle estimate off by 1.1-fold (0.03 log units), on the high side, and the stated range covers the measured number.
By their numbers in this assay, from the lowest: compounds 1, 3 and 2 (each within the scatter of the next).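

In this assay, ethoxy to butoxy leaves the read-out unresolved (a 1.1-fold lower number from compound 2 to compound 3 (0.04 log units; within the scatter)), so this lengthening of the chain gives no measurable shift. Butyl in place of hydrogen on the oxygen gives the same picture (a 1.0-fold higher number from compound 1 to compound 3 (0.01 log units; within the scatter)), and compound 1, compound 2 and compound 3 therefore fall in no order, with hydrogen, ethyl and butyl on this oxygen not told apart at this read-out. No measurement is available that would account for this flat result. Still open, as far as these compounds go, is whether a longer chain such as octyl would move the number beyond the scatter. Also open, from the compounds shown here alone, is whether an amine or a carboxylic acid at the end of the butyl chain would do so.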